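Swapping a Cyclopentyl Amide for a Methylthiazole Amide

The source may hold more compounds than are shown below. What is called first, only, known or untested is meant among the compounds shown, and "the series" means these compounds.

Measured compounds:
Compound 1, `C(#Cc1nc2c(s1)CN(C1CCCCC1)CC2)c1ccccc1`, gives > 10000 nM, a limit of the assay rather than a number.
Compound 2, `O=C(C1CC(F)C1)N1CCc2nc(C#Cc3ccccc3)sc2C1`, gives 85 nM.
Compound 3, `O=C(C1CCCC1)N1CCc2nc(C#Cc3ccccc3)sc2C1`, gives 19 nM.

These values come from an assay on HEK293 cells for positive allosteric modulation of metabotropic glutamate receptor 5 (Homo sapiens), read by FLIPR, with a stated time of 1 h; on this read-out lower numbers stand for an effect already at smaller amounts and higher numbers for an effect only at larger amounts of compound. Compound 3 stands at the lowest of the two numbers, with compound 2 nearest, and the change from compound 2 to compound 3 is a 4.5-fold lower number from compound 2 to compound 3 (0.65 log units; beyond the scatter). Compound 1, which carries a plain cyclohexyl on the ring amine nitrogen instead of an acyl group, sits at the limit of > 10000 nM in this assay, at which 1 of the 3 values shown sits.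

Compound 4, `Cc1nc(C(=O)N2CCc3nc(C#Cc4ccccc4)sc3C2)cs1`, has not yet been measured. It differs from compound 3 in one place: 2-methyl-1,3-thiazol-4-yl in place of cyclopentyl on a carbonyl carbon. The steps that touch this position are an at least 110-fold lower number from compound 1 to compound 2 (2.07 log units; beyond the scatter) and an at least 520-fold lower number from compound 1 to compound 3 (2.72 log units; beyond the scatter), both showing that placing a carbonyl-linked ring on the ring nitrogen gives a large improvement, and a 4.5-fold lower number from compound 2 to compound 3 (0.65 log units; beyond the scatter), a modest shift between two small saturated carbocycles. Within the data shown here, no measured step exchanges a saturated ring for an aromatic one on the carbonyl carbon, so the direction is uncertain; a change close to the scatter, possibly a small upward step, seems most plausible.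

Compound 4 is therefore expected to give 40 nM, with a likely range from 8 nM to 200 nM. That would be an expected step of a 2.1-fold higher number from compound 3 to compound 4 (0.32 log units; beyond the scatter).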

Compound 4, half-maximal effective concentration: 220 nM
For compound 4 the middle estimate is 5.5-fold (0.74 log units) below the measured one; measured number above the stated range.
By their numbers in this assay, from the lowest: compound 3; then compound 2; then compound 4. At a limit, above all of these: compound 1.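

Replacing the saturated cyclopentyl on the carbonyl carbon with the aromatic 2-methyl-1,3-thiazol-4-yl gives a 12-fold higher number from compound 3 to compound 4 (1.06 log units; beyond the scatter), so the group at this place matters more than the step between the two saturated rings alone could show. The comparison with the other saturated amide points the same way, with a 2.6-fold higher number from compound 2 to compound 4 (0.41 log units; beyond the scatter), which leaves the thiazole amide with the highest number of the three amides. The carbonyl-linked thiazole still gives an at least 45-fold lower number from compound 1 to compound 4 (1.65 log units; beyond the scatter), so this amide keeps much of the large gain over the plain cyclohexyl, although that step is only a bound, as compound 1 stands at a limit of the assay: the limit of > 10000 nM in this assay, at which 1 of the 4 values shown sits.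

With a single aromatic ring on the carbonyl carbon, these compounds cannot show whether the higher number goes with aromatic rings in general or with this particular thiazole and its methyl group. On these data alone, a phenyl group, a pyridyl group or the same thiazole without its methyl could help separate these possibilities, and it remains open whether any of them would come closer to compound 3 or to compound 4.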